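The source may hold more compounds than are shown below. What is called first, only, known or untested is meant among the compounds shown, and "the series" means these compounds.

Working notes on the series.

- compound 1, `CCOC(=O)c1c(Nc2ccc(I)cc2F)sc2c1CC(C)(C)CNC2=O`: "not determined" (no result reported) in a functional assay on HT-29 cells (Homo sapiens) for antiproliferative activity; on this read-out higher numbers stand for weaker inhibition and lower numbers for stronger inhibition
- compound 2, `CC1(C)CNC(=O)c2sc(Nc3ccc(I)cc3F)c(C(=O)NOCCO)c2C1`: 340 nM in this assay
- compound 3, `CC1(C)CNC(=O)c2sc(Nc3ccc(I)cc3F)c(C(=O)O)c2C1`: "not determined" (no result reported) in this assay

Among the measured compounds shown here, only one number is available across the three: compound 2 gives 340 nM in this assay. Compound 3, the carboxylic acid of the shared core, has no result, and compound 1 likewise has none, so compound 3 cannot be placed against any neighbour on the numbers shown; there is no measured step in the series at all.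

The next compound, compound 4 `CC(C)(N)CNC(=O)c1c(Nc2ccc(I)cc2F)sc2c1CC(C)(C)CNC2=O`, differs from compound 3 in one place: (2-amino-2-methylpropyl)amino in place of hydroxy on a carbonyl carbon. Whether this change moves this assay cannot be read from a measured pair. The closest reference is compound 2, itself an amide of the same acid with a value of 340 nM, and compound 4 is another amide of that acid. The expectation is therefore a step of no clear direction and of a size within, or not far beyond, the usual scatter relative to compound 2, with the uncertainty wide on both sides.

Compound 4 is expected to give about 300 nM in this assay, with a plausible range from 60 nM to 1500 nM.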

Compound 4, half-maximal inhibitory concentration: 79 nM
For compound 4 the middle estimate is 3.8-fold (0.58 log units) above the measured one; the range from low to high includes it.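

The carbonyl carbon of the shared core now has its first measured step: in this assay the series gives a 4.3-fold lower number from compound 2 to compound 4 (0.63 log units; beyond the scatter), with 2-amino-2-methylpropyl in place of 2-hydroxyethoxy on an amide-type nitrogen. The group carried on that nitrogen therefore matters for this read-out, since two amides of the same acid differ by more than the scatter, something compound 2 alone could not show. This rests on a single pair, and no measurement at hand bears on why the number falls.

Steps involving compound 1 or compound 3 cannot be read, so what the change from carboxy to (2-amino-2-methylpropyl)carbamoyl does by itself remains open. Also open, from the compounds shown here alone, is whether the lower number goes with the amine or with the two methyl groups of the chain, a question that a plain 2-aminoethyl chain and a 2-hydroxy-2-methylpropyl chain on the same amide nitrogen would separate.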